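The compounds below may be only part of what the source reports. "The series", "measured", "known", "first", "only" and "open" are said of these compounds alone.

Compound 1 `Cc1ccc(Cn2nnc(-c3cc([N+](=O)[O-])cc([N+](=O)[O-])c3)n2)cc1` shares its core with two measured analogues, compound 2 `O=[N+]([O-])c1cc(-c2nnn(Cc3cccc(Cl)c3)n2)cc([N+](=O)[O-])c1` and compound 3 `O=[N+]([O-])c1cc(-c2nnn(Cc3ccc(Br)cc3)n2)cc([N+](=O)[O-])c1`. In an ADME assay on CHO-K1 cells (Cricetulus griseus) for cytotoxicity, read by MTT assay, with a stated time of 24 h (on this read-out lower numbers stand for stronger inhibition and higher numbers for weaker inhibition), compound 1 gives 200000 nM, the highest of the three numbers; compound 2 gives 27000 nM and compound 3 gives 55000 nM. The steps of a 7.4-fold lower number from compound 1 to compound 2 (0.87 log units; beyond the scatter) and a 3.6-fold lower number from compound 1 to compound 3 (0.56 log units; beyond the scatter) both run downward, and a 2.0-fold higher number from compound 2 to compound 3 (0.31 log units; beyond the scatter) separates the two halogen-bearing analogues. Compound 4 `O=[N+]([O-])c1cc(-c2nnn(Cc3ccc(Cl)c(Cl)c3)n2)cc([N+](=O)[O-])c1` is not yet measured; it differs from compound 1 by 3,4-dichlorophenyl in place of 4-methylphenyl on a saturated chain carbon bound to an aromatic nitrogen, which resembles both earlier changes at once. Because of a 7.4-fold lower number from compound 1 to compound 2 (0.87 log units; beyond the scatter) and a 3.6-fold lower number from compound 1 to compound 3 (0.56 log units; beyond the scatter), compound 4 is expected to show a modest downward step, a 10-fold lower number from compound 1 to compound 4 (1.00 log units; beyond the scatter), giving an estimated 20000 nM with a range from 7000 nM to 60000 nM.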

Compound 4, half-maximal inhibitory concentration: 37000 nM
Beside the measured number, compound 4's estimate is 1.9-fold (0.27 log units) below it; measured number inside the range.
By their numbers in this assay, from the lowest: compounds 2, 4 and 3 (each within the scatter of the next, the first and the last beyond it); then compound 1.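

In this assay, 3,4-dichlorophenyl in place of 4-methylphenyl gives a 5.4-fold lower number from compound 1 to compound 4 (0.73 log units; beyond the scatter), so all three halogen-bearing compounds now read beyond the scatter from compound 1. Chloro in place of hydrogen on an aromatic carbon gives a 1.4-fold higher number from compound 2 to compound 4 (0.14 log units; within the scatter), and 3,4-dichlorophenyl in place of 4-bromophenyl gives a 1.5-fold lower number from compound 3 to compound 4 (0.17 log units; within the scatter); both are within the scatter, so this second chloro brings no readable change. Nothing here explains these numbers.

Going by these compounds, it remains open whether a plain phenyl would read like compound 1 or like the halogen-bearing compounds. On these data alone, how a phenyl carrying an amine or a carboxylic acid would read at this position is also open.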